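The source may report more compounds than this note shows. Statements on the series, on what has been measured and on what is new or still open speak of the compounds shown alone.

Measured so far:
compound 1, `N#Cc1ccccc1C1OCC(C/C=C\CCC(=O)O)C(c2cccnc2)O1`: > 100000 nM
compound 2, `CSc1ccc(OC(C)(C)C2OCC(C/C=C\CCC(=O)O)C(c3cccnc3)O2)c([N+](=O)[O-])c1`: 5000 nM

In an assay for inhibition of prostacyclin synthase (Homo sapiens), using microsomes (on this read-out higher numbers stand for weaker inhibition and lower numbers for stronger inhibition), compound 1 gives only a limit, > 100000 nM, recorded as the limit of > 100000 nM in this assay, at which 1 of the 2 values shown sits. In this assay compound 2 gives 5000 nM. Among the compounds with values here, that is the only number in the set; the other entry is a limit, so compound 2 stands alone as the sole measured point and has no measured neighbour to rank against.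

Compound 3, `CC(C)(Oc1ccc(F)cc1)C1OCC(C/C=C\CCC(=O)O)C(c2cccnc2)O1`, is not yet measured in this assay. It differs from compound 2 by a group of 7 heavy atoms (6 carbon, 1 fluorine; one six-membered aromatic ring of carbon only) in place of a group of 11 heavy atoms (7 carbon, 1 nitrogen, 2 oxygen, 1 sulfur; one six-membered aromatic ring of carbon only), on an oxygen on a saturated carbon. Within the data shown here, no step between two measured compounds differing in one place exists here, so this change has nothing measured to be sized against. The change is expected to cost little, at most a modest loss and possibly nothing beyond the scatter, a 1.6-fold higher number from compound 2 to compound 3 (0.20 log units; within the scatter). Compound 3 is therefore estimated at 8000 nM in this assay, with an expected range from 1500 nM to 40000 nM.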

Compound 3, half-maximal inhibitory concentration: 2000 nM
The estimate for compound 3 lay 4.0-fold (0.60 log units) above the measured number, within the range that was stated.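

In this assay, the oxygen on a saturated carbon now has its first measured step: placing 4-fluorophenyl there in place of the larger group gives a 2.5-fold lower number from compound 2 to compound 3 (0.40 log units; beyond the scatter). This position therefore accepts a group with no hydrogen-bond acceptors and without the nitrogen, sulfur and oxygen atoms of the group that leaves, and the number does not rise. Compound 1 remains a limit and not a number, so it gives no second measured point for the series: the limit of > 100000 nM in this assay, at which 1 of the 3 values shown sits.

With a single step, the fluorine cannot be separated from the loss of the other atoms, as these changes arrive together. As far as these compounds go, it stays open how an unsubstituted phenyl, a 4-chlorophenyl or a 4-aminophenyl group on that oxygen would read here.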